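The source may hold more compounds than are shown below. What is called first, only, known or untested is meant among the compounds shown, and "the series" means these compounds.

Measured in a functional assay on SK-BR-3 cells (Homo sapiens) for cytotoxicity, read by MTT assay, with a stated time of 72 h; on this read-out higher numbers stand for an effect only at larger amounts of compound and lower numbers for an effect already at smaller amounts:
- compound 1 `O=c1cc(NC2CC2)cc(-c2ccccc2)o1`: > 30 uM (limit)
- compound 2 `COc1ccc(Nc2cc(C)oc(=O)c2)cc1`: > 30 uM (limit)

Compound 2 stands at > 30 uM, which is a limit and not a number. Within the data shown here, the series so far offers only (the limit of > 30 uM in this assay, at which 2 of the 2 values shown sit). Compound 3 `CCCCCc1cc(Nc2ccc(OC)cc2)cc(=O)o1` differs from compound 2 by butyl in place of hydrogen on a saturated chain carbon bound to an aromatic carbon, which also reads as methyl to pentyl. Among the measured compounds shown here, no measured step is available as a guide, so a modest shift towards lower numbers is expected in this assay, and another limit remains possible. The estimated step is an at least 1.5-fold lower number from compound 2 to compound 3 (0.17 log units; that floor lies within the scatter). For compound 3 the expected value is 20 uM, with an estimated range of 6 uM to 60 uM.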

Compound 3, concentration for half-maximal effect: 4.93 uM
Beside the measured number, compound 3's estimate is 4.1-fold (0.61 log units) above it; measured number outside the range, below it.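

In this assay, among these compounds, the saturated chain carbon bound to an aromatic carbon is the first place where a change gives a measured number and not a limit. Methyl to pentyl at this place gives an at least 6.0-fold lower number from compound 2 to compound 3 (0.78 log units; beyond the scatter). That step has only a floor, as compound 2 stands at a limit: the limit of > 30 uM in this assay, at which 2 of the 3 values shown sit.

As far as these compounds go, whether a shorter chain such as propyl or a longer chain such as heptyl would give a lower or higher number remains open. So does whether a chain ending in an amine or a carboxylic acid at this place would keep the effect.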